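The compounds below may be only part of what the source reports. "The series", "measured", "known", "first", "only" and "open" are said of these compounds alone.

Working notes on the series. In an ADME assay on HepG2 cells (Homo sapiens) for cytotoxicity, read by MTT assay, with a stated time of 72 h (a higher number here means that more compound is tolerated, a lower number that less compound is tolerated), compound 1 (`O=[N+]([O-])c1c(CS(=O)(=O)c2ccccc2)nc2c(-c3ccccc3)cc(Cl)cn12`) gives > 15600 nM as a limit of the assay, not a number. Compound 2 (`CCN(CC)c1ccc(-c2cc(Cl)cn3c([N+](=O)[O-])c(CS(=O)(=O)c4ccccc4)nc23)cc1`) gives > 15600 nM in this assay, again only a limit, so its standing is known from one side alone. Within the data shown here, the one measured step, a step that the two limits leave unreadable from compound 1 to compound 2, carries no readable size. Among the measured compounds shown here, the series so far shows the limit of > 15600 nM in this assay, at which 2 of the 2 values shown sit, and nothing tighter.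

Compound 3 (`N#Cc1ccc(-c2cc(Cl)cn3c([N+](=O)[O-])c(CS(=O)(=O)c4ccccc4)nc23)cc1`) differs from compound 2 by cyano in place of diethylamino on an aromatic carbon, which is cyano in place of diethylamino on an aromatic carbon, or 4-(diethylamino)phenyl to 4-cyanophenyl. The step from compound 1 to compound 2 is the only one bearing on this position, and with it unreadable (a step that the two limits leave unreadable from compound 1 to compound 2), no size or direction can be taken from it. No step beyond the scatter is therefore expected in this assay, and the expected step reads a step that the limit leaves unreadable from compound 2 to compound 3 as an estimate only. For compound 3 the estimate is 20000 nM, with an expected range from 9000 nM to 50000 nM, and a further report as a limit is the likelier outcome.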

Compound 3, half-maximal cytotoxic concentration: > 3900 nM
Compound 3 ended at the assay's limit (the forecaster's own chance of this, stated with the estimate: 65%); the middle value is on the limit's open side.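

In this assay neither step into compound 3, from compound 1 or from compound 2, can be read: all three results are limits of the assay, not numbers. The compounds shown leave open where the half-maximal cytotoxic concentration of each actually lies, and whether hydrogen, diethylamino or cyano at this place makes any difference.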